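Swapping the Aromatic Substituent: What Compound 3 Should Show

A few compounds are considered here, and "the series" means these few. Any claim that something is new, unique, unknown or untested is made for them only; others in the source may bear on it.

compound 1 `O=C(C1CC1)N1CCN(Cc2nc3ccccc3n2Cc2ccc(F)cc2)CC1` — 32.7%
compound 2 `O=C(C1CC1)N1CCN(Cc2nc3ccccc3n2Cc2ccc(C(F)(F)F)cc2)CC1` — 37%

In an assay on isolated protein for inhibition of aldehyde dehydrogenase 1A1 (Homo sapiens), read by spectrophotometry, tested at 10 uM (on this read-out higher numbers stand for more inhibition at the one concentration tested (going by the name of the read-out) and lower numbers for less inhibition), compound 1 gives 32.7% and compound 2 gives 37%. Compound 2 holds the higher of the two numbers, yet the step of a number 4.3 percentage points higher from compound 1 to compound 2 (within the scatter) lies within the scatter, so no order between them can be claimed. Compound 3 `O=C(C1CC1)N1CCN(Cc2nc3ccccc3n2Cc2cccc(F)c2)CC1` differs from compound 2 in one place: 3-fluorophenyl in place of 4-(trifluoromethyl)phenyl on a saturated chain carbon bound to an aromatic nitrogen. Among the compounds with values here, the only step that bears on this change is the one from compound 1 to compound 2, and it was small. Compound 3 is therefore expected to show no step beyond the scatter, a number 4 percentage points lower from compound 2 to compound 3 (within the scatter). The inhibition of compound 3 is estimated at 33%, between 18% and 48%.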

Compound 3, a percentage reported as inhibition, at one concentration (the size of the read-out at that concentration, not a potency): 27.2%
Compound 3: the middle estimate sits 5.8 percentage points above what was measured; low and high end bracket the measured number.
By their numbers in this assay, from the lowest: compounds 3, 1 and 2 (each within the scatter of the next).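

In this assay, 3-fluorophenyl in place of 4-(trifluoromethyl)phenyl gives a number 9.8 percentage points lower from compound 2 to compound 3 (within the scatter), and 3-fluorophenyl in place of 4-fluorophenyl gives a number 5.5 percentage points lower from compound 1 to compound 3 (within the scatter). This position on a saturated chain carbon bound to an aromatic nitrogen has now taken three different phenyl groups with no step beyond the scatter, so none of these changes separates the compounds. Nothing available explains these numbers.

As far as these compounds go, whether any group at this place can move the inhibition beyond the scatter stays open. An amine or a carboxylic acid on the phenyl ring, or a longer chain to it, could test that.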